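A few compounds are considered here, and "the series" means these few. Any claim that something is new, unique, unknown or untested is made for them only; others in the source may bear on it.

Compound 1 `CCCCCCCCCCCCCCNC(=O)[C@H](CO)/N=C/c1cccc(OC)c1` gives 31300 nM
Compound 2 `CCCCCCCCCCCCCCNC(=O)[C@H](CO)/N=C/c1cccc(Cl)c1` gives 24100 nM
Compound 3 `CCCCCCCCCCCCCCNC(=O)[C@H](CO)/N=C/c1cccc(O)c1` has not yet been measured

For the measured compounds named here, in a functional assay on cells (Homo sapiens) for cytotoxicity, read by MTT assay, with a stated time of 24 h (a higher number here means a weaker inhibitor, a lower number a stronger inhibitor), compound 2 gives 24100 nM, and this lies within the usual scatter of compound 1 at 31300 nM, the only other number so far. The change to examine is hydroxy in place of chloro on an aromatic carbon. In words, it is hydroxy in place of chloro on an aromatic carbon, meta to a large group. Going by the values given here, one measured step bears on it, also an exchange of groups on an aromatic carbon: a 1.3-fold lower number from compound 1 to compound 2 (0.11 log units; within the scatter), with chloro in place of methoxy. Among the compounds with values here, a single step is thin evidence, and no compound carrying hydroxy has a measured value yet. Even so, no step beyond the scatter is expected in this assay, in either direction. The expected change is a 1.2-fold higher number from compound 2 to compound 3 (0.07 log units; within the scatter). For compound 3 the estimated value is 28000 nM, with an expected range of 14000 nM to 55000 nM.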

Compound 3, half-maximal inhibitory concentration: 32600 nM
Estimate against measurement, compound 3: 1.2-fold (0.07 log units) below; low and high end bracket the measured number.
By their numbers in this assay, from the lowest: compounds 2, 1 and 3 (each within the scatter of the next).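

In this assay, hydroxy in place of chloro on this aromatic carbon brings a hydrogen-bond donor and acceptor that chloro lacks, yet the step stays within the scatter (a 1.4-fold higher number from compound 2 to compound 3 (0.13 log units; within the scatter)). Hydrogen in place of methyl on the ring oxygen also stays within the scatter (a 1.0-fold higher number from compound 1 to compound 3 (0.02 log units; within the scatter)), so in this assay the three groups tested at this position, chloro, methoxy and hydroxy, cannot be told apart. No supporting measurement bears on why these numbers lie so close together.

As far as these compounds go, whether this holds only for small groups remains open, since an amine, a carboxylic acid or a larger ring substituent at this position could behave differently. The compounds shown also leave open how much the rest of the shared core matters, for example whether a shorter chain would change the number.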